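Swapping Butyl for Phenyl on an Amine Nitrogen

A few compounds are considered here, and "the series" means these few. Any claim that something is new, unique, unknown or untested is made for them only; others in the source may bear on it.

In a functional assay on T47D cells (Homo sapiens) for inhibition, read by sulforhodamine B assay, with a stated time of 48 h (on this read-out higher numbers stand for weaker inhibition of growth and lower numbers for stronger inhibition of growth), compound 1 (`COC(=[Se])Nc1ccc2c(C)cc(=O)oc2c1`) gives > 100000 nM, which is a limit of the assay and not a number. Compound 2 (`CCCCOC(=[Se])Nc1ccc2c(C)cc(=O)oc2c1`) gives "nd(insoluble)" (no result reported), so it offers no number to compare. Within the data shown here, compound 3 (`CCCCNC(=[Se])Nc1ccc2c(C)cc(=O)oc2c1`) gives 2900 nM, the only true number so far, and this makes it the natural reference point.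

The next compound is compound 4 (`Cc1cc(=O)oc2cc(NC(=[Se])Nc3ccccc3)ccc12`), which has phenyl in place of butyl on an amine nitrogen.

Among the measured compounds shown here, only one measured step bears on this change, and only indirectly. That step is an at least 34-fold lower number from compound 1 to compound 3 (1.53 log units; beyond the scatter), a large drop that came with butylamino in place of methoxy. For the measured compounds named here, compound 4 keeps the amine nitrogen that this step introduced, but no measured step changes the group carried on that nitrogen. The best anchor is therefore compound 3 with its 2900 nM. The expectation in this assay is a 1.0-fold higher number from compound 3 to compound 4 (0.01 log units; within the scatter), which means no expected shift beyond the scatter, with neither direction favoured and considerable uncertainty. For compound 4 the estimated value is 3000 nM, with an expected range from 800 nM to 15000 nM.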

Compound 4, concentration for 50% growth inhibition: 24000 nM
Compound 4: the middle estimate sits 8.0-fold (0.90 log units) below what was measured, outside the stated range (above it).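

In this assay, the group carried on the amine nitrogen clearly matters, since phenyl in place of butyl gives an 8.3-fold higher number from compound 3 to compound 4 (0.92 log units; beyond the scatter), so the nitrogen alone does not set the level of growth inhibition. Anilino in place of methoxy still gives an at least 4.1-fold lower number from compound 1 to compound 4 (0.61 log units; beyond the scatter), which means compound 4 keeps part of the gain seen with butylamino, where the change was an at least 34-fold lower number from compound 1 to compound 3 (1.53 log units; beyond the scatter). Both of these steps from compound 1 give only a minimum size, not an exact one, since compound 1 stands at a limit of the assay and not at a true number: the limit of > 100000 nM in this assay, at which 1 of the 4 values shown sits.

The compounds shown compare only one chain and one aromatic ring on this nitrogen, so they cannot tell whether the higher number for compound 4 goes with the aromatic ring itself or simply with replacing a chain by a ring, a question that a cyclohexyl group on the same nitrogen would address. On these data alone, how a benzyl group, a longer chain such as hexyl, or a phenyl ring carrying a chlorine would fare also stays open.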